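This account rests on a few compounds, and the source may have more. Where it says the series, first, only, none or still open, it means among the compounds named here.

Measured so far in a functional assay on A549 cells (Homo sapiens) for antiproliferative activity, read by MTT assay, with a stated time of 48 h; on this read-out higher numbers stand for weaker inhibition of growth and lower numbers for stronger inhibition of growth:
- compound 1 `CCCCCCN(Cc1ccc(C(=O)NO)cc1)c1ncc(-c2ccc(C)cc2)s1`, which gives 3710 nM
- compound 2 `Cc1ccc(OCCCN(Cc2ccc(C(=O)NO)cc2)c2ncc(-c3ccc(C)cc3)s2)cc1`, which gives 32500 nM
- compound 3 `Cc1ccc(-c2cnc(N(CCCCOc3ccccc3)Cc3ccc(C(=O)NO)cc3)s2)cc1`, which gives 14200 nM

Compound 3 stands second highest of the three numbers: compound 2 sits one modest step higher, and compound 1 a larger step lower. The unmeasured compound 4 `CCN(Cc1ccc(C(=O)NO)cc1)c1ncc(-c2ccc(C)cc2)s1` differs from compound 3 by hydrogen in place of 2-phenoxyethyl on a saturated chain carbon, two bonds along the chain from a nitrogen on an aromatic ring, so the chain on the nitrogen shrinks to a plain ethyl.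

Going by the values given here, two measured steps bear on this. Going from compound 1 to compound 3 gave a 3.8-fold higher number from compound 1 to compound 3 (0.58 log units; beyond the scatter), and from compound 1 to compound 2 gave an 8.8-fold higher number from compound 1 to compound 2 (0.94 log units; beyond the scatter): in both, adding an aryloxy group to the chain raised the number. Removing it again should therefore lower the number. Nothing shows how a shorter plain chain behaves, so the size is uncertain. Compound 4 is expected at about 4500 nM, within 1500 nM to 14000 nM, an estimated step of a 3.2-fold lower number from compound 3 to compound 4 (0.50 log units; beyond the scatter).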

Compound 4, concentration for 50% growth inhibition: 2700 nM
For compound 4 the middle estimate is 1.7-fold (0.22 log units) above the measured one; measured number inside the range.
By their numbers in this assay, from the lowest: compounds 4 and 1 (each within the scatter of the next); then compound 3; then compound 2.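

In this assay, the aryloxy-bearing chains now compare directly with a plain ethyl: hydrogen in place of 2-phenoxyethyl gives a 5.3-fold lower number from compound 3 to compound 4 (0.72 log units; beyond the scatter), and hydrogen in place of (4-methylphenoxy)methyl gives a 12-fold lower number from compound 2 to compound 4 (1.08 log units; beyond the scatter). The plain chains behave differently, since hydrogen in place of butyl gives a 1.4-fold lower number from compound 1 to compound 4 (0.14 log units; within the scatter), so for this pair the extra chain length alone leaves the number within the usual scatter and the higher numbers appear only in the two compounds carrying an aryloxy group. No measurement shown here explains why the aryloxy chains give higher numbers.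

As far as these compounds go, it remains open whether a chain ending in an amine or a carboxylic acid would follow the plain chains or the aryloxy ones. Also open, from the compounds shown here alone, is how a methyl, or a bare hydrogen, on the nitrogen would compare with the ethyl of compound 4.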